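The source may hold more compounds than are shown below. What is called first, only, known or untested is meant among the compounds shown, and "the series" means these compounds.

Of the compounds shown here, two have already been measured, and both carry the same core. Compound 1, `COc1ccc(-c2cc(=O)c3ccc(O)cc3o2)cc1OC`, gives 22.4 nM in a functional assay, read by spectrophotometry; on this read-out lower numbers stand for an effect already at smaller amounts and higher numbers for an effect only at larger amounts of compound. Compound 2, `COc1ccc(-c2cc(=O)c3ccc(OCCCCN4CCC(C)CC4)cc3o2)cc1`, gives 28.1 nM in this assay. Compound 2 thus carries the higher of the two numbers, but the gap to its nearest neighbour, compound 1, lies within the scatter of repeated measurements, so the two values are best read as equivalent.

The next member is compound 3, `COc1ccc(-c2cc(=O)c3ccc(OCCCCCCN4CCC(CCO)CC4)cc3o2)cc1`. It differs from compound 2 in one place: a group of 11 heavy atoms (9 carbon, 1 nitrogen, 1 oxygen; one six-membered non-aromatic ring with 1 hetero atom) in place of a group of 7 heavy atoms (6 carbon, 1 nitrogen; one six-membered non-aromatic ring with 1 hetero atom), on a saturated chain carbon, four bonds along the chain from an oxygen on an aromatic ring. The group that enters brings 1 hydrogen-bond donor and 2 hydrogen-bond acceptors where the group that leaves had none of the former and 1 of the latter.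

Going by the values given here, no measured pair in this set shows what such a change does, so the expectation must rest on compound 2 alone, whose value of 28.1 nM is the starting point. The step of a 1.1-fold higher number from compound 2 to compound 3 (0.03 log units; within the scatter) is expected to stay within the scatter, in no firm direction. Compound 3 is therefore estimated at 30 nM in this assay, with a range from 10 nM to 90 nM.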

Compound 3, half-maximal effective concentration: 34.4 nM
For compound 3 the middle estimate is 1.1-fold (0.06 log units) below the measured one; the range from low to high includes it.
By their numbers in this assay, from the lowest: compounds 1, 2 and 3 (each within the scatter of the next).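

Compound 1 and compound 2 offered no pair differing in one place, so the series had shown nothing about this position; the exchange of the 4-methylpiperidin-1-yl group for the group carrying a hydrogen-bond donor now supplies the first such step in this assay, namely a 1.2-fold higher number from compound 2 to compound 3 (0.09 log units; within the scatter). It shows that, on a saturated chain carbon, four bonds along the chain from an oxygen on an aromatic ring, a group with more heavy atoms and an added oxygen can enter while the two numbers remain equivalent on this read-out. Nothing available accounts for this outcome.

A single step cannot separate what the added oxygen contributes from what the added carbon atoms contribute, so the two remain bound together in this one result. As far as these compounds go, whether a carboxylic acid or a primary amine in place of that oxygen, or a still longer chain carrying the same six-membered ring, would give a step beyond the scatter in this assay remains open, as does how far this position accepts groups of other kinds.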